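The source may report more compounds than this note shows. Statements on the series, on what has been measured and on what is new or still open speak of the compounds shown alone.

The series shares one core, shown for compound 1 as `c1coc(CNc2nc(NCCCN3CCCC3)nc3ccccc23)c1`, for compound 2 as `CCCCCNc1nc(NCc2ccco2)c2cc(F)ccc2n1`, for compound 3 as `CCCCCNc1nc(NCc2ccco2)c2ccccc2n1` and for the unmeasured compound 4 as `CCCCNc1nc(NCc2ccco2)c2ccccc2n1`. All were set up for a functional assay on MCF7 cells (Homo sapiens) for cytotoxicity, read by MTT assay, with a stated time of 2 days, tested at 10 uM; a lower number here means less inhibition, a higher number more inhibition at the concentration tested (going by the name of the read-out). Compound 1 has no number there, its entry reading "not determined" (no result reported). Compound 2 is the only one with a figure: in this assay compound 2 gives 94.4%. Compound 3 likewise carries no number, its entry in this assay reading "not determined" (no result reported), so compound 3 stands without a place on the scale, and a second entry in the set is in the same position. Within the data shown here, no step between two measured compounds can be drawn from these data.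

The change from compound 3 to compound 4 is hydrogen in place of methyl on a saturated chain carbon, four bonds along the chain from a nitrogen on an aromatic ring. Compound 4 is therefore a one-carbon shortening of the pentyl chain of compound 3 to a butyl chain, with the furanylmethyl side left as it is. Among the measured compounds shown here, with no measured step to lean on, the expectation is that this change leaves the read-out within the scatter, in neither direction, resting on compound 2 with 94.4% as the only anchor for this chemotype. Compound 4 is expected to give about 85% in this assay, within a range from 50% to 100%.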

Compound 4, a percentage reported as inhibition, at one concentration (the size of the read-out at that concentration, not a potency): 66.7%
Compound 4: middle estimate off by 18.3 percentage points, on the high side; the measured number falls inside the stated range.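

Among these compounds, compound 3 has no number in this assay and so compound 4 at 66.7% yields no step that can be read from compound 3 to compound 4. The compounds shown leave open how the pentyl and butyl chains compare on the shared core. Nothing measured here offers an explanation for the value of compound 4.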